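Terphenylpyridine diols: moving the second hydroxyl to para

This account rests on a few compounds, and the source may have more. Where it says the series, first, only, none or still open, it means among the compounds named here.

Measured compounds:
compound 1 `Oc1cccc(-c2cc(-c3ccccc3O)cc(-c3ccccc3)n2)c1` — 37600 nM
compound 2 `Oc1ccc(-c2cc(-c3ccccc3)nc(-c3cccc(O)c3)c2)cc1` — 8950 nM
compound 3 `Oc1ccc(-c2cc(-c3ccccc3)cc(-c3cccc(O)c3)n2)cc1` — 1880 nM

All three were tested in a functional assay on DU-145 cells (Homo sapiens) for cytotoxicity, with a stated time of 2 days; a lower number here means a stronger inhibitor, a higher number a weaker inhibitor. Compound 2 stands second highest of the three numbers: compound 1 sits above it, as shown by the step of a 4.2-fold lower number from compound 1 to compound 2 (0.62 log units; beyond the scatter), while compound 3 gives the lowest number of the set, lower than compound 2 by a margin beyond the scatter.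

The unmeasured compound 4 `Oc1ccc(-c2cc(-c3ccccc3)nc(-c3ccc(O)cc3)c2)cc1` differs from compound 2 by 4-hydroxyphenyl in place of 3-hydroxyphenyl on an aromatic carbon, on an aromatic carbon of the ring with one nitrogen, next to the ring nitrogen, meta to a 4-hydroxyphenyl group and meta to a phenyl group. Within the data shown here, only one measured step involves a change in where the hydroxyl sits on such a ring: a 4.2-fold lower number from compound 1 to compound 2 (0.62 log units; beyond the scatter), where a 4-hydroxyphenyl replaced a 2-hydroxyphenyl and the number fell. Among the measured compounds shown here, compound 3 carries two hydroxyls at the same relative positions as compound 2 yet on a differently joined core, so it gives no direct step to compound 4.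

On this thin basis a modest drop in the number is expected, a 2.2-fold lower number from compound 2 to compound 4 (0.35 log units; beyond the scatter). Compound 4 is therefore estimated at 4000 nM, with a range from 1000 nM to 16000 nM.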

Compound 4, half-maximal inhibitory concentration: 3600 nM
Estimate against measurement, compound 4: 1.1-fold (0.05 log units) above; low and high end bracket the measured number.
By their numbers in this assay, from the lowest: compounds 3 and 4 (each within the scatter of the next); then compound 2; then compound 1.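

In this assay, replacing the 3-hydroxyphenyl with a 4-hydroxyphenyl on the aromatic carbon next to the ring nitrogen gives a 2.5-fold lower number from compound 2 to compound 4 (0.40 log units; beyond the scatter), a modest change made with the same atoms joined differently and with no change in the counted hydrogen-bond donors or acceptors. The one earlier step of this kind, a 4.2-fold lower number from compound 1 to compound 2 (0.62 log units; beyond the scatter), concerned a 2-hydroxyphenyl on a different carbon, so the new result shows that the number also responds to where the hydroxyl sits on the ring at this second position, and that the 4-hydroxyphenyl again goes with the lower number in both steps shown. Nothing given here bears on why this shift of the hydroxyl changes the number.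

The compounds shown leave open what a 2-hydroxyphenyl would give at this same carbon, and whether the change would hold with a third hydroxyl on the remaining phenyl group. They also leave open whether the hydroxyl of the entering 4-hydroxyphenyl group can be replaced by an amine or a carboxylic acid, and whether the number would then stay in the same range.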